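A few compounds are considered here, and "the series" means these few. Any claim that something is new, unique, unknown or untested is made for them only; others in the source may bear on it.

Compounds measured in a functional assay on A2780 cells (Homo sapiens) for antiproliferative activity, read by CellTiter-Glo, with a stated time of 72 h; a higher number here means a weaker inhibitor, a lower number a stronger inhibitor:
- compound 1 `O=C(Nc1ccc(CN2Cc3ccccc3C2=O)cc1)N1CC(c2cccnc2)C1`: 0.6 nM
- compound 2 `C[C@@H](c1ccc(NC(=O)N2CC(c3cccnc3)C2)cc1)N1Cc2ccccc2C1=O`: 1.5 nM
- compound 3 `C[C@H](NC(=O)C1CCOCC1)c1ccc(NC(=O)N2CC(c3ccc(N)nc3)C2)cc1`: 46 nM

Compound 1 has the lowest number of the three, and both gaps to it lie beyond the scatter. Compound 4 `O=C(Nc1ccc(Cn2c(=O)oc3ccccc32)cc1)N1CC(c2cccnc2)C1` keeps the core of compound 1 and changes one group, on a saturated chain carbon bound to an aromatic carbon: a group of 10 heavy atoms (7 carbon, 1 nitrogen, 2 oxygen; one five-membered aromatic ring with 2 hetero atoms, one six-membered aromatic ring of carbon only) in place of a group of 10 heavy atoms (8 carbon, 1 nitrogen, 1 oxygen; one five-membered non-aromatic ring with 1 hetero atom, one six-membered aromatic ring of carbon only), on a saturated chain carbon bound to an aromatic carbon. Among the compounds with values here, the only single-place step measured at that carbon is a 2.5-fold higher number from compound 1 to compound 2 (0.40 log units; beyond the scatter), which is modest and leaves the group itself in place. Within the data shown here, no measured step tests this swap, so the expectation is loose. The expected step in this assay is a 2.5-fold higher number from compound 1 to compound 4 (0.40 log units; beyond the scatter), modest and towards a higher number. For compound 4 the estimated value is 1.5 nM, with an expected range of 0.5 nM to 5 nM.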

Compound 4, half-maximal inhibitory concentration: 0.4 nM
Estimate against measurement, compound 4: 3.8-fold (0.57 log units) above; measured number below the stated range.
By their numbers in this assay, from the lowest: compounds 4 and 1 (each within the scatter of the next); then compound 2; then compound 3.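

In this assay, the earlier step at this saturated chain carbon only added a methyl, whereas this change replaces the whole group and gives a 1.5-fold lower number from compound 1 to compound 4 (0.18 log units; within the scatter) as the result. The group with one five-membered aromatic ring with 2 hetero atoms therefore cannot be told apart from the group it replaces, even though it has more hydrogen-bond acceptors. Nothing available bears on the reason for this result.

Still open, going by these compounds, is whether the methyl of compound 2 on this carbon would give the same step with the new group in place. Also open, on these data alone, is how a carboxylic acid or a longer chain would read at this place.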